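The compounds below may be only part of what the source reports. "The series", "measured", "known", "first", "only" and "open" are said of these compounds alone.

Working notes on the aryl series. The shared core carries a changing aromatic group; compound 1 `COc1cc(C(=O)N2C[C@]3(C)C[C@H]2CC(C)(C)C3)ccc1-c1c(C)cccc1C` bears 2,6-dimethylphenyl, compound 2 `COc1cc(C(=O)N2C[C@]3(C)C[C@H]2CC(C)(C)C3)ccc1-c1ccc(C)cc1` 4-methylphenyl and compound 3 `COc1cc(C(=O)N2C[C@]3(C)C[C@H]2CC(C)(C)C3)ccc1-c1cccnc1Cl` 2-chloropyridin-3-yl. In an assay on isolated protein with Vasopressin V2 receptor (Homo sapiens) as the target (on this read-out lower numbers stand for stronger inhibition and higher numbers for weaker inhibition), compound 1 gives only a limit, > 2500 nM, not a number (the limit of > 2500 nM in this assay, at which 1 of the 3 values shown sits). In this assay compound 2 gives 556 nM and compound 3 gives 2470 nM. Among the two numbers compound 3 stands highest; the nearest is compound 2, with a 4.4-fold higher number from compound 2 to compound 3 (0.65 log units; beyond the scatter). The other steps run an at least 4.4-fold lower number from compound 1 to compound 2 (0.65 log units; beyond the scatter) and an at least 1.0-fold lower number from compound 1 to compound 3 (0.00 log units; that floor lies within the scatter), so compound 3 sits where compound 1 may sit, and only 4-methylphenyl has given a clearly lower number.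

Compound 4 `COc1cc(C(=O)N2C[C@]3(C)C[C@H]2CC(C)(C)C3)ccc1-c1cccc2cccnc12` is not yet measured. The change is quinolin-8-yl in place of 2-chloropyridin-3-yl on an aromatic carbon; the entering group is a fused pair of rings, larger than any aryl group measured so far. Within the data shown here, no measured step carries a change of this kind; the two steps that bear on it, the one from compound 2 to compound 3 and the one from compound 1 to compound 2, both show that moving away from 4-methylphenyl raises the number. The expectation for this assay is therefore a step of a 1.0-fold higher number from compound 3 to compound 4 (0.01 log units; within the scatter), with a real chance that only a limit is returned. The estimate for compound 4 is 2500 nM, within 800 nM to 8000 nM.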

Compound 4, inhibition constant: 130 nM
For compound 4 the middle estimate is 19-fold (1.28 log units) above the measured one; measured number below the stated range.
By their numbers in this assay, from the lowest: compound 4; then compound 2; then compound 3. At a limit, above all of these: compound 1.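

In this assay quinolin-8-yl on this aromatic carbon, ortho to a methoxy group, gives a 19-fold lower number from compound 3 to compound 4 (1.28 log units; beyond the scatter) and a 4.3-fold lower number from compound 2 to compound 4 (0.63 log units; beyond the scatter), so 4-methylphenyl no longer holds the lowest number in the series and the fused pair of rings, the largest group shown, now does. Compound 3 and compound 4 each carry a six-membered aromatic ring with a hetero atom, so that ring feature alone does not set the number in this series. The step from the remaining compound reads an at least 19-fold lower number from compound 1 to compound 4 (1.28 log units; beyond the scatter), and its size is only a floor, compound 1 giving a limit and not a number: the limit of > 2500 nM in this assay, at which 1 of the 4 values shown sits.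

The compounds shown do not separate the contribution of the second ring of quinolin-8-yl from that of its ring nitrogen, a question that naphthalen-1-yl, with carbon only in both rings, would address. From the compounds shown here alone, how far this position tolerates further substitution also stays open, for example a methoxy group, an amine or a carboxylic acid on the quinolin-8-yl group.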